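A few compounds are considered here, and "the series" means these few. Any claim that something is new, unique, unknown or untested is made for them only; others in the source may bear on it.

In a functional assay on L1210 cells (Mus musculus) for cytotoxicity, read by cell counting, with a stated time of 48 h (on this read-out higher numbers stand for weaker inhibition and lower numbers for stronger inhibition), compound 2 (`Nc1nc(Cl)nc2ccsc12`) gives > 250000 nM, a limit and not a number. Compound 1 (`Clc1ncc2sccc2n1`) gives > 250000 nM, also a limit. Compound 3 (`Clc1nc(-n2cncn2)c2sccc2n1`) gives > 250000 nM, again a limit. The whole set sits there: the limit of > 250000 nM in this assay, at which 3 of the 3 values shown sit. Compound 4 (`Nc1nc(Cl)nc2c(Br)csc12`) differs from compound 2 as follows: bromo in place of hydrogen on an aromatic carbon. The measured steps nearest to it are a step that the two limits leave unreadable from compound 1 to compound 2, a step that the two limits leave unreadable from compound 1 to compound 3 and a step that the two limits leave unreadable from compound 2 to compound 3. None has a readable size and none involves bromo, so they set no firm size for this change. A modest move towards stronger inhibition is expected, with a real chance of another limit. The expected step is an at least 2.5-fold lower number from compound 2 to compound 4 (0.39 log units; beyond the scatter). The estimate for compound 4 is 100000 nM, with an expected range of 20000 nM to 250000 nM.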

Compound 4, half-maximal inhibitory concentration: 150000 nM
Compound 4: middle estimate off by 1.5-fold (0.18 log units), on the low side; the range from low to high includes it.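

Bromo on an aromatic carbon of the five-membered aromatic ring, two ring bonds from the ring sulfur, gives the only readable number in the series, with an at least 1.6-fold lower number from compound 2 to compound 4 (0.22 log units; that floor lies within the scatter). The floor of that step does not establish a change larger than the usual scatter in this assay. The steps among compound 1, compound 2 and compound 3 cannot be read, and only compound 4 stands clear of the shared limit: the limit of > 250000 nM in this assay, at which 3 of the 4 values shown sit.

Going by these compounds, it remains open whether iodo or methyl on the same carbon would give a readable number. On these data alone, it also remains open whether bromo would do so on compound 3.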